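The source may hold more compounds than are shown below. What is called first, only, known or untested is meant among the compounds shown, and "the series" means these compounds.

Compounds measured so far:
compound 1 `COc1cccc(Sc2c(/C=C/[C@@H]3C[C@@H](O)CC(=O)O3)cnc3cc(Cl)c(F)cc23)c1` — in an assay (strain Holtzman-Sprague-Dawley) for inhibition of 3-hydroxy-3-methylglutaryl-coenzyme A reductase (Rattus norvegicus), with a stated time of 30 min (a lower number here means a stronger inhibitor, a higher number a weaker inhibitor), compound 1 gives 9240 nM
compound 2 `O=C1C[C@H](O)C[C@@H](/C=C/c2cnc3c(Sc4ccc(F)cc4)c(Sc4ccc(F)cc4)c(F)cc3c2Sc2ccc(F)cc2)O1` — compound 2 gives 11900 nM
compound 3 `COc1cccc(Sc2cc3ncc(/C=C/[C@@H]4C[C@@H](O)CC(=O)O4)c(Sc4cccc(OC)c4)c3cc2F)c1` — compound 3 gives 3640 nM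

Compound 1 holds the second highest of the three numbers; compound 2 sits within the scatter of it, while compound 3 is set apart by a 2.5-fold lower number from compound 1 to compound 3 (0.40 log units; beyond the scatter), a change of (3-methoxyphenyl)sulfanyl in place of chloro on an aromatic carbon. Compound 4 `CC(C)c1ccc(Sc2c(/C=C/[C@@H]3C[C@@H](O)CC(=O)O3)cnc3cc(Cl)c(F)cc23)cc1` differs from compound 1 by 4-isopropylphenyl in place of 3-methoxyphenyl on a sulfur. For the measured compounds named here, no measured pair exchanges the group on this sulfur; the single step, a 2.5-fold lower number from compound 1 to compound 3 (0.40 log units; beyond the scatter), concerns a different change and gives no bearing here. Accordingly no step beyond the scatter is expected, the estimated step being a 1.0-fold lower number from compound 1 to compound 4 (0.01 log units; within the scatter). For compound 4 the expected value is 9000 nM, with a range of 3000 nM to 27000 nM.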

Compound 4, half-maximal inhibitory concentration: 22100 nM
Compound 4: the middle estimate sits 2.5-fold (0.39 log units) below what was measured; the range from low to high includes it.
By their numbers in this assay, from the lowest: compound 3; then compounds 1, 2 and 4 (each within the scatter of the next, the first and the last beyond it).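

In this assay, the group on this sulfur proves able to shift the number, with a 2.4-fold higher number from compound 1 to compound 4 (0.38 log units; beyond the scatter) when 4-isopropylphenyl replaces 3-methoxyphenyl. For the compounds shown here, this is a modest change, but it is the first reading for this position, and it goes toward weaker inhibition. No available evidence explains the step.

Going by these compounds alone, the single exchange changes both the substituent and its printed ring position, so the contribution of each remains unresolved. Also open, on these data alone, is how this sulfur position would respond to a phenyl ring carrying an amine or a carboxylic acid.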